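Aryl swap at the biaryl position: compound 3

The source may report more compounds than this note shows. Statements on the series, on what has been measured and on what is new or still open speak of the compounds shown alone.

Compound 1 `CC(C)N(Cc1cccc(OCCCCCC(=O)O)c1)C(=O)c1ccc(-c2cccc3ccccc23)cc1` opens the pair. In an ADME assay on BJ cells (Homo sapiens) for cytotoxicity, read by CellTiter-Glo and resazurin assay, with a stated time of 72 h (a lower number here means that less compound is needed, a higher number that more compound is needed for the effect), compound 1 gives < 1.3 nM, which is a limit of the assay rather than a number (the limit of < 1.3 nM in this assay, at which 1 of the 2 values shown sits). Compound 2 `CC(C)Oc1cccc(-c2ccc(C(=O)N(Cc3cccc(OCCCCCC(=O)O)c3)C(C)C)cc2)c1` gives > 26000 nM in this assay, again only a limit (the limit of > 26000 nM in this assay, at which 1 of the 2 values shown sits). The step of an at least 20000-fold higher number from compound 1 to compound 2 (4.30 log units; beyond the scatter) is thus large, towards more compound needed. Compound 3 `CC(C)N(Cc1cccc(OCCCCCC(=O)O)c1)C(=O)c1ccc(-c2ccsc2)cc1` differs from compound 2 by thiophen-3-yl in place of 3-isopropoxyphenyl on an aromatic carbon. Going by the values given here, only that measured step bears on this change; it shows the aromatic group at this place can shift the read-out greatly, and thiophen-3-yl is neither group measured, so the size of any move is uncertain. Compound 3 is expected at 5000 nM (range 300 nM to 26000 nM), an estimated step of an at least 5.2-fold lower number from compound 2 to compound 3 (0.71 log units; beyond the scatter).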

Compound 3, half-maximal effective concentration: > 26000 nM
Compound 3 was reported as a limit; the forecaster's own chance of this, stated with the estimate: 35%; at least 5.2-fold (0.71 log units) between middle value and limit.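

In this assay the result adds a second replacement for naphthalen-1-yl, a five-membered aromatic ring with 1 hetero atom, and the read-out again stops at a limit: the limit of > 26000 nM in this assay, at which 2 of the 3 values shown sit. Thiophen-3-yl in place of naphthalen-1-yl gives an at least 20000-fold higher number from compound 1 to compound 3 (4.30 log units; beyond the scatter), so the large shift does not depend on the 3-isopropoxyphenyl group alone. The step between compound 2 and compound 3 cannot be read, as both values are limits.

Open, going by these compounds, is whether naphthalen-2-yl or a phenyl carrying an amine at this place would bring the number back towards that of compound 1.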